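This account rests on a few compounds, and the source may have more. Where it says the series, first, only, none or still open, it means among the compounds named here.

On these data alone, compound 1 `CC1=CC[C@@H]([C@@](C)(O)CCCC(C)(C)NC(=S)NN)CC1` carries a free amino group at the end of its thiosemicarbazide-free shared core; in a functional assay on PCO3 cells (Homo sapiens) for cytotoxicity, read by sulforhodamine B assay (on this read-out lower numbers stand for stronger inhibition of growth and higher numbers for weaker inhibition of growth), compound 1 gives only a limit, > 100000 nM, so its true value is unknown, as the limit of > 100000 nM in this assay, at which 1 of the 3 values shown sits, records. Two close relatives do give numbers. Compound 2 `CC1=CC[C@@H]([C@@](C)(O)CCCC(C)(C)NC(=S)N/N=C\c2ccc(O)cc2)CC1` gives 13900 nM in this assay, and compound 3 `CC1=CC[C@@H]([C@@](C)(O)CCCC(C)(C)NC(=S)N/N=C\c2cccc([N+](=O)[O-])c2)CC1` gives 20700 nM. The step of an at least 7.1-fold lower number from compound 1 to compound 2 (0.85 log units; beyond the scatter) shows that replacing the amino group by an aromatic arm brings growth inhibition into the measurable range, while a 1.5-fold higher number from compound 2 to compound 3 (0.17 log units; within the scatter) shows that swapping the substituent on that aromatic ring changes little.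

Compound 4 `CC1=CC[C@@H]([C@@](C)(O)CCCC(C)(C)NC(=S)N/N=C\c2ccccc2Cl)CC1` makes the same kind of change as compound 2: a group of 9 heavy atoms (7 carbon, 1 nitrogen, 1 chlorine; one six-membered aromatic ring of carbon only) in place of one nitrogen atom, on an amide-type nitrogen. Since compound 2 and compound 3 both landed in a similar region after this kind of replacement, compound 4 is expected to show the step of an at least 5.8-fold lower number from compound 1 to compound 4 (0.76 log units; beyond the scatter). Compound 4 is therefore estimated at 17000 nM in this assay, with a plausible range from 6000 nM to 50000 nM.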

Compound 4, concentration for total growth inhibition: > 100000 nM
Compound 4: a limit, no number; the forecaster's own chance of this, stated with the estimate: 10%; middle value at least 5.8-fold (0.76 log units) away from the limit.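

The aromatic arm alone therefore does not guarantee measurable growth inhibition. With 2-chlorophenyl on the carbon with a double bond to nitrogen, the read-out shows an at least 4.8-fold higher number from compound 3 to compound 4 (0.68 log units; beyond the scatter), and likewise an at least 7.1-fold higher number from compound 2 to compound 4 (0.85 log units; beyond the scatter), so the choice of ring and substituent at this position can matter, which the close pair of compound 2 and compound 3 gave no sign of. The step from compound 1 to compound 4 cannot be read, since compound 4 gives only a limit, as compound 1 does: the limit of > 100000 nM in this assay, at which 2 of the 4 values shown sit.

The three aromatic arms shown differ in both the substituent and the way it is attached, so these results cannot say which of the two separates compound 4 from compound 2 and compound 3. On these data alone, how a plain phenyl ring, or a methoxy group in place of the chlorine, would behave remains open.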